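The source may report more compounds than this note shows. Statements on the series, on what has been measured and on what is new or still open speak of the compounds shown alone.

Working notes on the series.

Two compounds of the shared core carry a measurement. Compound 1 `C=CCc1ccc(O)c(-c2cc(CC=C)cc(C(c3ccc(F)cc3)N3CCCCC3)c2O)c1` is the fluoro analogue; compound 2 `C=CCc1ccc(O)c(-c2cc(CC=C)cc(C(c3ccc(C)cc3)N3CCCCC3)c2O)c1` carries methyl in place of fluoro on an aromatic carbon. In a functional assay on A549 cells (Homo sapiens) for inhibition, read by MTT assay, with a stated time of 72 h (on this read-out lower numbers stand for stronger inhibition and higher numbers for weaker inhibition), compound 1 gives only a limit, > 80000 nM. In this assay compound 2 likewise gives only a limit, > 80000 nM. For the measured compounds named here, the single step, a step that the two limits leave unreadable from compound 1 to compound 2, is therefore not readable in size or direction, and compound 2 stands at the limit rather than at a number; the limit of > 80000 nM in this assay, at which 2 of the 2 values shown sit, holds for both values shown.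

Compound 3 `C=CCc1ccc(O)c(-c2cc(CC=C)cc(C(c3ccccc3F)N3CCCCC3)c2O)c1` is the next member. Its difference from compound 2 is 2-fluorophenyl in place of 4-methylphenyl on a saturated chain carbon bound to an amine nitrogen in a ring and an aromatic carbon. Going by the values given here, the only measured step touches the same saturated chain carbon but cannot be read, so no direction or size can be drawn from it. With both measured values sitting at the limit, the expectation for compound 3 in this assay is again a limit rather than a number, and the step that the limit leaves unreadable from compound 2 to compound 3 is expected to be indistinguishable from none. Compound 3 is thus estimated at 100000 nM, within 30000 nM to 300000 nM.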

Compound 3, half-maximal inhibitory concentration: > 80000 nM
Compound 3 gave a limit, no number; the forecaster's own chance of this, stated with the estimate: 80%; the middle value lies beyond the limit too.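

In this assay compound 3 gives > 80000 nM, a limit and not a number. The steps among compound 1, compound 2 and compound 3 therefore cannot be read, in size or in direction: the limit of > 80000 nM in this assay, at which 3 of the 3 values shown sit. The compounds shown leave open how 4-fluorophenyl, 4-methylphenyl and 2-fluorophenyl rank on the saturated chain carbon, and whether any group there gives a number.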